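The source may hold more compounds than are shown below. What is called first, only, known or untested is meant among the compounds shown, and "the series" means these compounds.

In a functional assay on HCT-116 cells (Homo sapiens) for inhibition, read by MTT assay, with a stated time of 72 h (a higher number here means a weaker inhibitor of growth, a lower number a stronger inhibitor of growth), compound 1 `CC(c1ccccc1)N1CCN(c2c(Cl)cnc3[nH]c(-c4ccc(N(C)C)cc4)nc23)CC1` gives 900 nM, the lower of the two numbers measured; compound 2 `O=C(CN1CCN(c2c(Br)cnc3[nH]c(-c4ccccc4)nc23)CC1)Nc1nccs1` gives 3000 nM in this assay, and the two differ in several places, so their gap cannot be tied to one change. Compound 3 `CN(C)c1ccc(-c2nc3c(N4CCN(CC(=O)Nc5cccc(Cl)c5)CC4)c(Cl)cnc3[nH]2)cc1` is not yet measured. It differs from compound 1 as follows: ((3-chlorophenyl)carbamoyl)methyl in place of 1-phenylethyl on an amine nitrogen in a ring. Going by the values given here, no single-change step is available to guide this, so the author expects a small weakening, near the scatter, with the estimated step of a 1.7-fold higher number from compound 1 to compound 3 (0.22 log units; within the scatter) for compound 3. Compound 3 is thus estimated at 1500 nM in this assay, between 500 nM and 5000 nM.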

Compound 3, concentration for 50% growth inhibition: 2670 nM
For compound 3 the middle estimate is 1.8-fold (0.25 log units) below the measured one, within the range that was stated.
By their numbers in this assay, from the lowest: compound 1; then compounds 3 and 2 (each within the scatter of the next).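

Going by these compounds alone, on the amine nitrogen in a ring, ((3-chlorophenyl)carbamoyl)methyl in place of 1-phenylethyl gives a 3.0-fold higher number from compound 1 to compound 3 (0.47 log units; beyond the scatter) in this assay as the first step that can be tied to one change. This position therefore responds to its substituent, yet the entering group, with its carbonyl and amide hydrogen, keeps growth inhibition with only a modest loss. No measurement bears on what lies behind this step.

On these data alone, whether the loss belongs to the amide link or to the chlorine on the phenyl ring stays open. A carboxylic acid or a simple acetyl group on the same nitrogen would further test how much this position accepts.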